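The compounds below may be only part of what the source reports. "The series", "measured", "known", "first", "only" and "open" are said of these compounds alone.

Working notes on the series. Compound 3 `COC(=O)/C=C/c1cccc(N(Cc2ccc(-c3ccc(C)cc3)cc2)C(=O)C(C)C)c1` in an assay on isolated protein with Bile acid receptor (Homo sapiens) as the target (a higher number here means that more compound is needed for the effect, a lower number that less compound is needed), gives 118 nM, the highest of the three numbers, yet within the scatter of compound 1 `COC(=O)/C=C/c1cccc(N(Cc2ccc(-c3ccc(OC)cc3)cc2)C(=O)C(C)C)c1` at 97 nM and of compound 2 `COC(=O)/C=C/c1cccc(N(Cc2ccc(-c3cccc(Cl)c3)cc2)C(=O)C(C)C)c1` at 77 nM. Compound 4 `COC(=O)/C=C/c1cccc(N(Cc2ccc(/C=C/c3cccc(Cl)c3)cc2)C(=O)C(C)C)c1` is not yet measured; the change is 2-(3-chlorophenyl)ethenyl in place of 4-methylphenyl on an aromatic carbon. Going by the values given here, the steps that bear on it are a 1.5-fold higher number from compound 2 to compound 3 (0.19 log units; within the scatter) and a 1.2-fold higher number from compound 1 to compound 3 (0.09 log units; within the scatter), both within the scatter, so the 3-chlorophenyl piece itself moved little. Among the compounds with values here, no measured pair shows an ethenyl link inserted before the outer ring, so that part of the change is uncharted. The expected step is therefore a 1.3-fold lower number from compound 3 to compound 4 (0.12 log units; within the scatter), not beyond the scatter. Compound 4 is estimated at 90 nM, with a range from 35 nM to 250 nM.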

Compound 4, half-maximal effective concentration: 164 nM
For compound 4 the middle estimate is 1.8-fold (0.26 log units) below the measured one; the measured number falls inside the stated range.
By their numbers in this assay, from the lowest: compounds 2, 1, 3 and 4 (each within the scatter of the next, the first and the last beyond it).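

In this assay, going by these compounds alone, the ethenyl link before the 3-chlorophenyl ring gives the first step beyond the scatter, and a modest one: a 2.1-fold higher number from compound 2 to compound 4 (0.33 log units; beyond the scatter). The other two steps, a 1.4-fold higher number from compound 3 to compound 4 (0.14 log units; within the scatter) and a 1.7-fold higher number from compound 1 to compound 4 (0.23 log units; within the scatter), lie within the scatter, so at this position the change separates compound 4 only from compound 2. Nothing at hand gives a reason for this step.

Open, as far as these compounds go, are an ethyl link in place of the ethenyl link and the ethenyl link bearing another outer ring. From the compounds shown here alone, a carboxylic acid in place of the methyl ester is also open.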